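One aromatic group swapped in a small series

The source may report more compounds than this note shows. Statements on the series, on what has been measured and on what is new or still open speak of the compounds shown alone.

In a functional assay on SMMC-7721 cells (Homo sapiens) for cytotoxicity, read by MTT assay, with a stated time of 24 h (on this read-out higher numbers stand for weaker inhibition and lower numbers for stronger inhibition), compound 1 `COc1cc(/C=C2\CN(S(=O)(=O)c3ccc(F)cc3)C/C(=C\c3cc(OC)cc(OC)c3)C2=O)cc(OC)c1` gives 8210 nM, compound 2 `COc1cc(/C=C2\CN(S(=O)(=O)c3ccc(F)cc3)C/C(=C\c3ccccc3F)C2=O)cc(OC)c1OC` gives 6340 nM and compound 3 `COc1cc(/C=C2\CN(S(=O)(=O)c3ccc(F)cc3)C/C(=C\c3cccc([N+](=O)[O-])c3)C2=O)cc(OC)c1OC` gives 4900 nM, so compound 3 stands within the scatter of the other two. Compound 4 `COc1cc(/C=C2\CN(S(=O)(=O)c3ccc(F)cc3)C/C(=C\c3cc(OC)c(OC)c(OC)c3)C2=O)cc(OC)c1` differs from compound 3 by one change: 3,5-dimethoxyphenyl in place of 3-nitrophenyl on a double-bonded chain carbon bound to a double-bonded ring carbon. Within the data shown here, the single measured step at this place, a 1.3-fold lower number from compound 2 to compound 3 (0.11 log units; within the scatter), stayed within the scatter. Compound 1, which also carries 3,5-dimethoxyphenyl, gives 8210 nM, a number in the same band. No step beyond the scatter is therefore expected in this assay, in either direction. The expected step is a 1.2-fold higher number from compound 3 to compound 4 (0.09 log units; within the scatter). Compound 4 is estimated at 6000 nM, with an expected range from 3000 nM to 12000 nM.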

Compound 4, half-maximal inhibitory concentration: 5420 nM
Estimate against measurement, compound 4: 1.1-fold (0.04 log units) above; measured number inside the range.
By their numbers in this assay, from the lowest: compounds 3, 4, 2 and 1 (each within the scatter of the next).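

In this assay, a third aromatic group at this place again leaves the number within the scatter, with a 1.1-fold higher number from compound 3 to compound 4 (0.04 log units; within the scatter) and a 1.2-fold lower number from compound 2 to compound 4 (0.07 log units; within the scatter) as the two steps. A second kind of change, methoxy in place of hydrogen on an aromatic carbon, also stays within the scatter, giving a 1.5-fold lower number from compound 1 to compound 4 (0.18 log units; within the scatter) as its step. No measurement shown explains why these steps are so small.

All the groups at this place are substituted phenyl rings, so an amine, a carboxylic acid or a longer chain there remains an open test.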